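This account rests on a few compounds, and the source may have more. Where it says the series, first, only, none or still open, it means among the compounds named here.

Measured compounds:
compound 1, `COC(=O)/C=C/c1cccc(N(C)C(=O)C2CCCCC2)c1`, > 1000 nM;
compound 2, `COC(=O)/C=C/c1cccc(N(Cc2ccc(/C=C/C(=O)OC(C)(C)C)cc2OC)C(=O)C2CCCCC2)c1`, > 1000 nM.

Both values are limits. In an assay on isolated protein with Bile acid receptor (Homo sapiens) as the target (a higher number here means that more compound is needed for the effect, a lower number that less compound is needed), compound 1 gives > 1000 nM, a limit of the assay and not a number. In this assay compound 2 likewise gives > 1000 nM, again a limit rather than a measured number. For the measured compounds named here, compound 2 thus sits at the edge of what the assay resolves, at the limit of > 1000 nM in this assay, at which 2 of the 2 values shown sit, and no measured step between compound 1 and compound 2 can be drawn from two limits. Compound 3, `COC(=O)/C=C/c1cccc(N(Cc2ccc(/C=C/C(=O)OC(C)(C)C)cc2OCc2ccccc2)C(=O)C2CCCCC2)c1`, differs from compound 2 in one place: phenyl in place of hydrogen on a saturated chain carbon bound to an oxygen on an aromatic ring. Going by the values given here, no measured step covers a change of this kind. The expected step that the limit leaves unreadable from compound 2 to compound 3 is small and without a direction established beyond the scatter. Compound 3 is expected to give 3000 nM in this assay, in the range 800 nM to 20000 nM, most likely reported again as a limit.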

Compound 3, half-maximal effective concentration: > 1000 nM
Compound 3 ended at the assay's limit; the forecaster's own chance of this, stated with the estimate: 75%; the middle value does not contradict the limit.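

For the compounds shown here, compound 2 and compound 3 both stand at a limit in this assay and no step from methoxy to benzyloxy can be read between them: the limit of > 1000 nM in this assay, at which 3 of the 3 values shown sit.
The compounds shown leave open how far each lies from that limit and which change to the shared core would give a measurable value.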